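Shifting the Chlorine Pattern from Compound 3 to Compound 4

A few compounds are considered here, and "the series" means these few. Any claim that something is new, unique, unknown or untested is made for them only; others in the source may bear on it.

In a functional assay on PC-3 cells (Homo sapiens) for antiproliferative activity, read by MTT assay, tested at 5 uM (a higher number here means a stronger effect of the compound at the concentration tested, a lower number a weaker effect), compound 3 `COc1cc(C(=O)N/N=C/c2ccc(Cl)c(Cl)c2)cc(OC)c1OC` gives 31.6%, the lowest of the three numbers seen: compound 1 `COc1cc(C(=O)N/N=C/c2ccc(F)c(F)c2)cc(OC)c1OC` gives 43.7% and compound 2 `COc1cc(C(=O)N/N=C/c2cccc(F)c2)cc(OC)c1OC` gives 64.1%. The measured steps are a number 20.4 percentage points higher from compound 1 to compound 2 (beyond the scatter), a number 12.1 percentage points lower from compound 1 to compound 3 (beyond the scatter) and a number 32.5 percentage points lower from compound 2 to compound 3 (beyond the scatter). Compound 4 `COc1cc(C(=O)N/N=C/c2cc(Cl)cc(Cl)c2)cc(OC)c1OC` differs from compound 3 by 3,5-dichlorophenyl in place of 3,4-dichlorophenyl on a carbon with a double bond to nitrogen. Among the measured compounds shown here, none of the measured steps moves a halogen from one position to another; each of them changes which halogen is present, so no direct guide to this change exists among the three compounds. Compound 4 is expected to give about 35%, within 20% to 52%, the expected step of a number 3.4 percentage points higher from compound 3 to compound 4 (within the scatter) staying within the scatter.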

Compound 4, a percentage reported as inhibition, at one concentration (the size of the read-out at that concentration, not a potency): 46.3%
For compound 4 the middle estimate is 11.3 percentage points below the measured one, within the range that was stated.
By their numbers in this assay, from the lowest: compound 3; then compounds 1 and 4 (each within the scatter of the next); then compound 2.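

In this assay, keeping both chlorines and changing only their pattern gives a number 14.7 percentage points higher from compound 3 to compound 4 (beyond the scatter), so on this carbon with a double bond to nitrogen the pattern matters as well as the halogen present. The 3,5-dichlorophenyl group still falls short of 3-fluorophenyl with a number 17.8 percentage points lower from compound 2 to compound 4 (beyond the scatter) and, set against 3,4-difluorophenyl, gives a number 2.6 percentage points higher from compound 1 to compound 4 (within the scatter). No evidence given here explains these steps. The compounds shown leave open how the 3,5-pattern behaves with fluorine in place of chlorine, and how an amine or a nitrile would read in that place.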